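A few compounds are considered here, and "the series" means these few. Any claim that something is new, unique, unknown or untested is made for them only; others in the source may bear on it.

Values in a functional assay for agonist activity at growth hormone secretagogue receptor type 1 (Homo sapiens), read by FLIPR (on this read-out lower numbers stand for an effect already at smaller amounts and higher numbers for an effect only at larger amounts of compound), for the measured compounds:

compound 1 `COc1ccc(N2C[C@@H](C)N[C@@H](C)C2)cc1NS(=O)(=O)c1ccc(-c2ccccc2)cc1` — 6.31 nM
compound 2 `COc1ccc(F)c(-c2ccc(S(=O)(=O)Nc3cc(N4C[C@@H](C)N[C@@H](C)C4)ccc3OC)cc2)c1` — 0.398 nM
compound 3 `COc1ccc(N2C[C@@H](C)N[C@@H](C)C2)cc1NS(=O)(=O)c1ccc(-c2ccncc2)cc1` — 316 nM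

Compound 3 stands highest of the three: it lies above compound 1 by a 50-fold higher number from compound 1 to compound 3 (1.70 log units; beyond the scatter) and above compound 2 by a 790-fold higher number from compound 2 to compound 3 (2.90 log units; beyond the scatter). Compound 4 `COc1ccc(N2C[C@@H](C)N[C@@H](C)C2)cc1NS(=O)(=O)c1ccc(-c2cncnc2)cc1` differs from compound 3 by pyrimidin-5-yl in place of pyridin-4-yl on an aromatic carbon. Going by the values given here, no measured pair exchanges one ring with hetero atoms for another; the steps that bear on this change are those into compound 3, where a ring with one hetero atom replaced phenyl and the number rose strongly in both cases. A second hetero atom in that ring is therefore expected to move the number further in the same direction, or to leave it near compound 3, by a 3.2-fold higher number from compound 3 to compound 4 (0.50 log units; beyond the scatter). Compound 4 is estimated at 1000 nM, within 300 nM to 4000 nM.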

Compound 4, half-maximal effective concentration: 316 nM
Compound 4: the middle estimate sits 3.2-fold (0.50 log units) above what was measured, within the range that was stated.
By their numbers in this assay, from the lowest: compound 2; then compound 1; then compounds 3 and 4 (each within the scatter of the next).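

In this assay, pyrimidin-5-yl in place of pyridin-4-yl on an aromatic carbon para to a large group gives no change at the digits printed from compound 3 to compound 4 (within the scatter), so the ring with 2 hetero atoms does not separate from the ring with 1 hetero atom. The gap to the carbon-only rings stays large: a 50-fold higher number from compound 1 to compound 4 (1.70 log units; beyond the scatter) and a 790-fold higher number from compound 2 to compound 4 (2.90 log units; beyond the scatter). No measurement at hand accounts for this result.

Open remains whether pyridin-3-yl, or a pyridine ring carrying an amine, would come closer to the carbon-only rings.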